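Chloro for methyl on the aryl urea of compound 1

The source may report more compounds than this note shows. Statements on the series, on what has been measured and on what is new or still open speak of the compounds shown alone.

The series is followed in an assay on isolated protein for displacement of a labelled ligand from metabotropic glutamate receptor 5 (Homo sapiens); on this read-out lower numbers stand for stronger inhibition and higher numbers for weaker inhibition. Compound 1, `Cc1cnccc1NC(=O)/N=C1\NC(=O)CN1C`, gives 2670 nM in this assay and so sits at the high end of the three numbers recorded. Compound 3, `CN1CC(=O)N/C1=N\C(=O)Nc1ccccc1`, gives 1360 nM, which lies within the usual scatter of the number for compound 1. Compound 2, `Cc1cccc(C#Cc2ccccn2)n1`, gives 39 nM, a value beyond the scatter from compound 1 and far away from it.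

The step now taken leads from compound 1 to compound 4, `CN1CC(=O)N/C1=N\C(=O)Nc1ccncc1Cl`, not yet measured in this assay. The change is chloro in place of methyl on an aromatic carbon, on an aromatic carbon of a six-membered aromatic ring with 1 nitrogen, ortho to a large group and two atoms from the ring nitrogen. No measured pair in this set shows such an exchange, so no shown step can anchor its size. The analogues compound 1 and compound 3 both sit in the same region of this assay, so a step of no more than the scatter is expected, in either direction.

Compound 4 is therefore estimated at 2200 nM, with a range from 700 nM to 7000 nM. The step from compound 1 to compound 4 that this estimate implies is expected to be a 1.2-fold lower number from compound 1 to compound 4 (0.08 log units; within the scatter).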

Compound 4, half-maximal inhibitory concentration: 663 nM
Compound 4: middle estimate off by 3.3-fold (0.52 log units), on the high side; measured number outside the range, below it.
By their numbers in this assay, from the lowest: compound 2; then compound 4; then compounds 3 and 1 (each within the scatter of the next).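

In this assay, chloro in place of methyl on this aromatic carbon, ortho to a large group and two atoms from the ring nitrogen, gives a 4.0-fold lower number from compound 1 to compound 4 (0.60 log units; beyond the scatter). This is the first exchange at this position among the compounds shown, and it reveals that the number responds to a swap of one heavy atom for another, with no change in the counted hydrogen-bond donors, hydrogen-bond acceptors or net charge. Nothing measured here bears on why the number falls.

From the compounds shown here alone, whether bromo, methoxy or nitrile on the same carbon would lower the number further or raise it again remains open. Also open, going by these compounds, is whether the step from methyl to chloro would keep its size on a ring without the nitrogen, the ring carried by compound 3.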